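The source may hold more compounds than are shown below. What is called first, only, known or untested is meant among the compounds shown, and "the series" means these compounds.

Compound 1, `C=C1C(=O)O[C@H]2[C@@H]1[C@@H](OC(=O)C=C(C)C)C[C@@](C)(O)[C@@]13C=C[C@@](C)(OO1)[C@H]23`, is the starting point of this account. In a functional assay on RAW264.7 cells (Mus musculus) for inhibition, read by Griess assay, with a stated time of 18 h (on this read-out higher numbers stand for weaker inhibition and lower numbers for stronger inhibition), compound 1 gives 7200 nM. Compound 2, `C=C1C(=O)O[C@H]2[C@H]1CC[C@@](C)(O)[C@]13C=C[C@](C)([C@@H]21)[C@]1(C3)C(=O)O[C@H]2[C@H]1C[C@@H](O)[C@@](C)(O)[C@]13O[C@H]1[C@@H](O)[C@](C)(O)[C@H]23`, reaches only a limit of the assay in this assay, at > 50000 nM, and so gives no number; this is the limit of > 50000 nM in this assay, at which 1 of the 2 values shown sits. Among the two results shown, compound 1 therefore carries the only measured number, the other being a limit. Compound 3, `C=C1C(=O)O[C@H]2[C@@H]1[C@@H](OC(=O)/C(C)=C/C)C[C@@](C)(O)[C@@]13C=C[C@@](C)(OO1)[C@H]23`, differs from compound 1 in one place: 1-methylprop-1-en-1-yl in place of 2-methylprop-1-en-1-yl on a carbonyl carbon. The same four carbons are kept, joined differently on the carbonyl carbon. Among the compounds with values here, no step between two measured compounds is available to guide the size of such a change, so the expected step of a 1.0-fold lower number from compound 1 to compound 3 (0.01 log units; within the scatter) is small and within the usual scatter, with no clear direction. On that basis compound 3 is estimated to give 7000 nM in this assay, within a range from 3000 nM to 17000 nM.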

Compound 3, half-maximal inhibitory concentration: 3400 nM
Estimate against measurement, compound 3: 2.1-fold (0.31 log units) above, and the stated range covers the measured number.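

In this assay, the place on a carbonyl carbon whose other neighbour is an oxygen next to a carbonyl group responds to a rearrangement of the same four carbons: a 2.1-fold lower number from compound 1 to compound 3 (0.33 log units; beyond the scatter). Within the data shown here, this is the first step that can be read here, and it shows that swapping 2-methylprop-1-en-1-yl for 1-methylprop-1-en-1-yl is enough to move the number beyond the usual scatter, though only modestly. Nothing measured here bears on why this step occurs. The compounds shown carry only these two groups at this place, so how a longer chain, a phenyl ring or an amine would read there remains open. From the compounds shown here alone, whether the same swap gives a similar step on any other core also remains open.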